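Fluoro to bromo on the aryl group of compound 2

The source may report more compounds than this note shows. Statements on the series, on what has been measured and on what is new or still open speak of the compounds shown alone.

Compound 1 `CCOC(=O)CCCCCOc1cccc(CN(C(=O)c2ccc(-c3ccc4c(c3)OCCO4)cc2)C(C)C)c1` gives > 24400 nM, a limit.
Compound 2 `CCOC(=O)CCCCCOc1cccc(CN(C(=O)c2ccc(-c3cccc(F)c3)cc2)C(C)C)c1` gives > 26000 nM, a limit.

Both entries come from an ADME assay on HepG2 cells (Homo sapiens) for cytotoxicity, read by CellTiter-Glo and resazurin assay, with a stated time of 72 h; on this read-out lower numbers stand for an effect already at smaller amounts and higher numbers for an effect only at larger amounts of compound. Compound 2 therefore has no numerical position in the series, only its limit: the limit of > 26000 nM in this assay, at which 1 of the 2 values shown sits. For the measured compounds named here, the one other reading is also a limit: the limit of > 24400 nM in this assay, at which 1 of the 2 values shown sits.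

Compound 3 `CCOC(=O)CCCCCOc1cccc(CN(C(=O)c2ccc(-c3cccc(Br)c3)cc2)C(C)C)c1` has bromo in place of fluoro on an aromatic carbon, turning 3-fluorophenyl into 3-bromophenyl: bromo in place of fluoro on an aromatic carbon. Going by the values given here, one measured step bears on this change, as it also alters the group that compound 2 carries as 3-fluorophenyl. That step is a step that the two limits leave unreadable from compound 1 to compound 2, and it gives neither a size nor a direction. With no readable step to carry over, no step beyond the usual scatter is expected in this assay, and a further limit is the likeliest report. The expected step is an at least 1.0-fold lower number from compound 2 to compound 3 (0.01 log units; that floor lies within the scatter). For compound 3 the estimate is 25000 nM, with an expected range from 12000 nM to 45000 nM.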

Compound 3, half-maximal effective concentration: > 26000 nM
Compound 3: no number, only a limit; the forecaster's own chance of this, stated with the estimate: 80%; at least 1.0-fold (0.01 log units) between middle value and limit.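

In this assay compound 3 gives > 26000 nM, a limit. The steps among compound 1, compound 2 and compound 3 cannot be read, as all three entries are limits. Still open is whether the 3-bromophenyl, 3-fluorophenyl and 2,3-dihydro-1,4-benzodioxin-6-yl groups differ at all in this assay, and where any of these compounds would give a numerical value.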